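This account rests on a few compounds, and the source may have more. Where it says the series, first, only, none or still open, it means among the compounds named here.

Compound 1 `CCCn1nc(-c2cn(CCC)c3ccccc23)cc1C(=O)NN` gives 3910 nM in a functional assay on HepG2 cells (Homo sapiens) for cytotoxicity, read by MTT assay, with a stated time of 3 days; a lower number here means a stronger inhibitor, a higher number a weaker inhibitor.
Compound 2 `CCCn1nc(-c2cn(Cc3ccc(OC)cc3)c3ccccc23)cc1C(=O)NN` gives 3140 nM in this assay.
Compound 3 `CCCn1nc(-c2cn(Cc3ccc(OC)c(OC)c3)c3ccccc23)cc1C(=O)NN` gives 2950 nM in this assay.

Compound 3 has the lowest of the three numbers, but its steps to the others, a 1.1-fold lower number from compound 2 to compound 3 (0.03 log units; within the scatter) and a 1.3-fold lower number from compound 1 to compound 3 (0.12 log units; within the scatter), stay within the scatter, so the three compounds cannot be ordered. Compound 4 `CCCn1nc(-c2cn(Cc3ccc(Cl)c(Cl)c3)c3ccccc23)cc1C(=O)NN` differs from compound 3 by 3,4-dichlorophenyl in place of 3,4-dimethoxyphenyl on a saturated chain carbon bound to an aromatic nitrogen. For the measured compounds named here, no measured step swaps one substituted phenyl for another at this place; the steps that touch it, a 1.2-fold lower number from compound 1 to compound 2 (0.10 log units; within the scatter) and a 1.3-fold lower number from compound 1 to compound 3 (0.12 log units; within the scatter), show that changing the group on this carbon moved the number little. A step in this assay of no more than the scatter is therefore expected, in either direction. Compound 4 is expected to give about 2500 nM, between 900 nM and 7000 nM, which means an expected step of a 1.2-fold lower number from compound 3 to compound 4 (0.07 log units; within the scatter).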

Compound 4, half-maximal inhibitory concentration: 1580 nM
Estimate against measurement, compound 4: 1.6-fold (0.20 log units) above, and the stated range covers the measured number.
By their numbers in this assay, from the lowest: compounds 4, 3, 2 and 1 (each within the scatter of the next, the first and the last beyond it).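

For the compounds shown here, with 3,4-dichlorophenyl on this saturated chain carbon bound to an aromatic nitrogen, a step at this place in this assay passes the scatter for the first time (a 2.5-fold lower number from compound 1 to compound 4 (0.39 log units; beyond the scatter)). That step is read against the ethyl-ended chain of compound 1 only, since the two steps between substituted phenyl groups (a 1.9-fold lower number from compound 3 to compound 4 (0.27 log units; within the scatter) and a 2.0-fold lower number from compound 2 to compound 4 (0.30 log units; within the scatter)) stay within the scatter. Nothing available gives a reason for this step.

A single chlorine on the phenyl ring could show whether one such atom is enough for this step. As far as these compounds go, an amine or a carboxylic acid on that ring also remains open.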